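The compounds below may be only part of what the source reports. "The series", "measured", "known", "first", "only" and "open" are said of these compounds alone.

Measured in an ADME assay on J774.1 cells (Mus musculus) for cytotoxicity, read by resazurin assay, with a stated time of 48 h; on this read-out higher numbers stand for weaker inhibition and lower numbers for stronger inhibition:
- compound 1 `CCCCn1cc(C(=O)NCc2ccccc2)c(=O)c2cc(F)c(N(C)C)cc21`: > 100000 nM
- compound 2 `CCCn1cc(C(=O)NCc2ccco2)c(=O)c2cc(F)c(N3CCC(C(N)=O)CC3)cc21`: 56900 nM

Compound 1 stands at a limit of this assay, not at a number: > 100000 nM.

Compound 3 `CCCCn1cc(C(=O)NCc2ccccc2)c(=O)c2cc(F)c(N3CCC(C(N)=O)CC3)cc21` carries 4-carbamoylpiperidin-1-yl in place of dimethylamino on an aromatic carbon, ortho to a fluoro group: 4-carbamoylpiperidin-1-yl in place of dimethylamino on an aromatic carbon.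

Compound 2 also carries 4-carbamoylpiperidin-1-yl and gives 56900 nM. On that basis, a modest step toward stronger inhibition in this assay is expected, with the estimated step of an at least 2.0-fold lower number from compound 1 to compound 3 (0.30 log units; that floor lies within the scatter). For compound 3 the expected value is 50000 nM, with an estimated range of 20000 nM to 100000 nM.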

Compound 3, half-maximal inhibitory concentration in the J774.1 assay: 47000 nM
Compound 3: middle estimate off by 1.1-fold (0.03 log units), on the high side; measured number inside the range.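

In the J774.1 assay, 4-carbamoylpiperidin-1-yl in place of dimethylamino on this aromatic carbon gives an at least 2.1-fold lower number from compound 1 to compound 3 (0.32 log units; beyond the scatter), a step read at a single place, with compound 3 at 47000 nM. Compound 1 differs from compound 2 in more than one place, and compound 2, which in the J774.1 assay gives 56900 nM, could not supply this step. In a physicochemical assay for lipophilicity, read by HPLC (on this read-out lower numbers stand for lower lipophilicity and higher numbers for higher lipophilicity), the same exchange gives no change at the digits printed from compound 1 to compound 3 (within the scatter): compound 1 gives 2.4 and compound 3 gives 2.4. The first step is only a floor, as compound 1 stands at a limit: the limit of > 100000 nM in the J774.1 assay, at which 1 of the 3 values shown sits.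

On these data alone, whether the step belongs to the ring or to the carbamoyl group stays open. Also open, as far as these compounds go, is what an unsubstituted piperidin-1-yl or a carboxylic acid in place of the carbamoyl group would give on this carbon.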